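This account rests on a few compounds, and the source may have more. Where it says the series, first, only, none or still open, it means among the compounds named here.

Measured compounds in a functional assay on NCI-H1299 cells (Homo sapiens) for inhibition, read by CCK-8 assay, with a stated time of 72 h, tested at 1 uM; a higher number here means a stronger effect of the compound at the concentration tested, a lower number a weaker effect:

Compound 1, `CN(C)C(=O)c1cc2cnc(Nc3ccc(S(=O)(=O)NCCCN=C=S)cc3)nc2n1C1CCCC1`, gives 41.3% in this assay.
Compound 2, `CN(C)C(=O)c1cc2cnc(Nc3ccc(S(=O)(=O)NCCCCN=C=S)cc3)nc2n1C1CCCC1`, gives 29.9% in this assay.
Compound 3, `CN(C)C(=O)c1cc2cnc(Nc3ccc(S(=O)(=O)NCCCCCCN=C=S)cc3)nc2n1C1CCCC1`, gives 42.4% in this assay.

All three share one core and differ only in the chain that ends in the isothiocyanate group. Going from compound 1 to compound 2 the change is a group of 4 heavy atoms (2 carbon, 1 nitrogen, 1 sulfur; no ring) in place of a group of 3 heavy atoms (1 carbon, 1 nitrogen, 1 sulfur; no ring), on a saturated chain carbon, three bonds along the chain from a sulfonamide nitrogen, and it brought a number 11.4 percentage points lower from compound 1 to compound 2 (beyond the scatter). Going from compound 1 to compound 3 the change is a group of 6 heavy atoms (4 carbon, 1 nitrogen, 1 sulfur; no ring) in place of a group of 3 heavy atoms (1 carbon, 1 nitrogen, 1 sulfur; no ring), on a saturated chain carbon, three bonds along the chain from a sulfonamide nitrogen, and here the two values sit within the scatter of each other, so nothing can be said about order.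

Compound 4, `CN(C)C(=O)c1cc2cnc(Nc3ccc(S(=O)(=O)NCCCCCCCN=C=S)cc3)nc2n1C1CCCC1`, has not yet been measured in this assay. It differs from compound 3 by a group of 4 heavy atoms (2 carbon, 1 nitrogen, 1 sulfur; no ring) in place of a group of 3 heavy atoms (1 carbon, 1 nitrogen, 1 sulfur; no ring), on a saturated chain carbon, six bonds along the chain from a sulfonamide nitrogen. Going by the values given here, this is the same kind of change as the one from compound 1 to compound 2, though the place is not the same: there the new group sat three bonds along the chain from the sulfonamide nitrogen, here six bonds along. Among the compounds with values here, since the only measured step of this kind is the drop seen in compound 1 to compound 2, a drop is expected from compound 3 to compound 4 as well, of about a number 7.4 percentage points lower from compound 3 to compound 4 (within the scatter), though with little confidence, since only one such step has been measured. Compound 4 is therefore estimated at 35%, with a likely range from 23% to 47%.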

Compound 4, a percentage reported as inhibition, at one concentration (the size of the read-out at that concentration, not a potency): 58.9%
The estimate for compound 4 lay 23.9 percentage points below the measured number; measured number outside the range, above it.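

In this assay the new step is a number 16.5 percentage points higher from compound 3 to compound 4 (beyond the scatter) and so runs the opposite way to the earlier lengthening of the chain by the same kind of change: the same change on two cores in this assay, a number 11.4 percentage points lower (beyond the scatter) from compound 1 to compound 2 and a number 16.5 percentage points higher (beyond the scatter) from compound 3 to compound 4, 27.9 percentage points apart, beyond the scatter of two such steps. The longer steps also favour compound 4, with a number 17.6 percentage points higher from compound 1 to compound 4 (beyond the scatter) and a number 29 percentage points higher from compound 2 to compound 4 (beyond the scatter) and the second of these does not match the earlier step of the same kind: the same change on two cores in this assay, a number 1.1 percentage points higher (within the scatter) from compound 1 to compound 3 and a number 29 percentage points higher (beyond the scatter) from compound 2 to compound 4, 27.9 percentage points apart, beyond the scatter of two such steps. This shows that the effect of adding to this chain cannot be carried from one chain length to another in this series, but it does not show why, and each comparison rests on a single pair of values at one concentration.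

The compounds shown leave open how a longer chain than that of compound 4 would behave and whether the rise would continue. They also leave open what happens when the isothiocyanate at the chain end gives way to another group, such as an amine or a carboxylic acid.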